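The source may report more compounds than this note shows. Statements on the series, on what has been measured and on what is new or still open speak of the compounds shown alone.

In a functional assay on MV4-11 cells (Homo sapiens) for antiproliferative activity, read by CellTiter-Glo, with a stated time of 72 h (a lower number here means a stronger inhibitor of growth, a higher number a weaker inhibitor of growth), compound 1 `Fc1cc(-c2csc(NCC3CCOCC3)n2)c(Cl)cn1` gives > 10000 nM, which is a limit and not a number. Compound 2 `COCCNc1cc(-c2csc(NCC3CCOCC3)n2)c(Cl)cn1` gives > 10000 nM, also a limit, so it has no exact potency to start from. Both compounds stand at the limit of > 10000 nM in this assay, at which 2 of the 2 values shown sit. Compound 3 `Clc1cnc(Nc2ccccc2)cc1-c1csc(NCC2CCOCC2)n1` differs from compound 2 at one place: phenyl in place of 2-methoxyethyl on a nitrogen on an aromatic ring. For the measured compounds named here, the only measured guide is a step that the two limits leave unreadable from compound 1 to compound 2, so no firm size can be carried over, and at most a modest gain in growth inhibition is expected in this assay. The expected change is an at least 1.4-fold lower number from compound 2 to compound 3 (0.15 log units; that floor lies within the scatter). Compound 3 is estimated at 7000 nM, with an expected range of 1000 nM to 10000 nM.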

Compound 3, concentration for 50% growth inhibition: > 10000 nM
Compound 3 ended at the assay's limit; the forecaster's own chance of this, stated with the estimate: 60%; middle value at least 1.4-fold (0.15 log units) away from the limit.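

Compound 1, compound 2 and compound 3 all sit at a limit in this assay, so no step among them can be read: the limit of > 10000 nM in this assay, at which 3 of the 3 values shown sit.

The compounds shown leave open whether any change at this nitrogen can bring growth inhibition into a measurable range.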